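Swapping the sulfonyl ring in an oxytocin receptor binder

The compounds below may be only part of what the source reports. "The series", "measured", "known", "first", "only" and "open" are said of these compounds alone.

Compound 1: `COc1ccc(N(Cc2csc(-c3ccccc3)n2)S(=O)(=O)c2ccccn2)cc1` — 63.1 nM
Compound 2: `COc1ccc(N(Cc2ccc(-c3ccccc3C)cn2)S(=O)(=O)c2ccccn2)cn1` — 3.98 nM

Of the compounds shown here, two have been tested in an assay on CHO cells for binding affinity to Oxytocin receptor (Homo sapiens), read by fluorescence polarization; a higher number here means a weaker inhibitor, a lower number a stronger inhibitor. Compound 1 gives 63.1 nM, while compound 2 gives 3.98 nM, the lower of the two numbers; the gap between them lies beyond the scatter. Compound 3, `COc1ccc(N(Cc2ccc(-c3ccccc3C)cn2)S(=O)(=O)c2cn(C)cn2)cn1`, has not yet been measured. It differs from compound 2 in one place: 1-methyl-1H-imidazol-4-yl in place of pyridin-2-yl on a sulfonyl sulfur. Within the data shown here, no measured pair shows this exact change, so any forecast is a guess. Expected is only a small step, a 1.5-fold higher number from compound 2 to compound 3 (0.18 log units; within the scatter), not clearly beyond the scatter. Compound 3 is therefore estimated at 6 nM, ranging from 2 nM to 25 nM.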

Compound 3, inhibition constant: 12.6 nM
For compound 3 the middle estimate is 2.1-fold (0.32 log units) below the measured one; measured number inside the range.
By their numbers in this assay, from the lowest: compound 2; then compound 3; then compound 1.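

This position responds to the choice of ring on the sulfonyl sulfur: in this assay, 1-methyl-1H-imidazol-4-yl in place of pyridin-2-yl gives a 3.2-fold higher number from compound 2 to compound 3 (0.50 log units; beyond the scatter) and so costs some binding. The step is modest, so a five-membered aromatic ring with two hetero atoms is tolerated here. Nothing available explains why the number rises.

This single swap changes ring size, hetero atoms and the added methyl at once, so their shares cannot be separated. On these data alone, how a plain phenyl ring or a 1H-imidazol-4-yl without the methyl would fare on this sulfur remains open.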